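A few compounds are considered here, and "the series" means these few. Any claim that something is new, unique, unknown or untested is made for them only; others in the source may bear on it.

Compound 2 `COc1ccc(C(=O)/C=C/c2cc(-c3cc(OC)c(OC)c(OC)c3)n[nH]2)cc1OC` stands lowest of the two numbers in a functional assay on M14 cells (Homo sapiens) for inhibition, read by sulforhodamine B assay, with a stated time of 48 h (on this read-out lower numbers stand for stronger inhibition of growth and higher numbers for weaker inhibition of growth), where compound 2 gives 1840 nM; compound 1 `COc1cc(-c2cc(/C=C/C(=O)c3ccc(Cl)c(Cl)c3)[nH]n2)cc(OC)c1OC` gives 18200 nM, and a 9.9-fold lower number from compound 1 to compound 2 (1.00 log units; beyond the scatter) came with 3,4-dimethoxyphenyl in place of 3,4-dichlorophenyl on a carbonyl carbon. Compound 3 `COc1ccc(C(=O)/C=C/c2cc(-c3cc(OC)c(OC)c(OC)c3)n[nH]2)cc1` carries the change (hydrogen in place of methoxy on an aromatic carbon), hydrogen in place of methoxy on an aromatic carbon. Among the measured compounds shown here, only the step from compound 1 to compound 2 bears on it, as it altered the same ring on the carbonyl carbon; with one methoxy removed, a modest step toward a higher number in this assay is expected, a 1.9-fold higher number from compound 2 to compound 3 (0.28 log units; within the scatter). For compound 3 the estimate is 3500 nM, within 1000 nM to 12000 nM.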

Compound 3, concentration for 50% growth inhibition: 2200 nM
Estimate against measurement, compound 3: 1.6-fold (0.20 log units) above; the range from low to high includes it.
By their numbers in this assay, from the lowest: compounds 2 and 3 (each within the scatter of the next); then compound 1.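

In this assay hydrogen in place of methoxy on the aromatic carbon gives no separable shift (a 1.2-fold higher number from compound 2 to compound 3 (0.08 log units; within the scatter)), so 4-methoxyphenyl and 3,4-dimethoxyphenyl on the carbonyl carbon read alike here. Against 3,4-dichlorophenyl the single methoxy still holds most of the gap (an 8.3-fold lower number from compound 1 to compound 3 (0.92 log units; beyond the scatter)), so the second methoxy is not required for it. No evidence on the cause of this is available. Open, from the compounds shown here alone, is whether the remaining methoxy matters at all, and how an amine, a carboxylic acid or a longer chain such as ethoxy would read on this ring.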